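A few compounds are considered here, and "the series" means these few. Any claim that something is new, unique, unknown or untested is made for them only; others in the source may bear on it.

For the measured compounds named here, compound 2 `CC#CC(CC(=O)O)c1ccc(OCc2cccc(-c3c(C)cc(OCCCS(C)(=O)=O)cc3C)c2)s1` stands highest of the two numbers so far in a functional assay on cells for agonist activity at Free fatty acid receptor 1 (Homo sapiens), read by calcium flux (on this read-out lower numbers stand for an effect already at smaller amounts and higher numbers for an effect only at larger amounts of compound), where compound 2 gives 240 nM. Its nearest neighbour, compound 1 `CC#C[C@@H](CC(=O)O)c1ccc(OCc2cccc(-c3c(C)cc(OCCCS(C)(=O)=O)cc3C)c2)s1`, gives 81 nM in this assay, and the step of a 3.0-fold higher number from compound 1 to compound 2 (0.47 log units; beyond the scatter) is the only measured one, with the fact that one of compounds 1 and 2 is drawn with a defined configuration and the other without, at the place where they differ as the single point of difference between them.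

The next step leads to compound 3 `CC#C[C@H](CC(=O)O)c1ccc(OCc2cccc(-c3c(C)cc(OCCCS(C)(=O)=O)cc3C)c2)s1`, whose change from compound 2 is the two compounds have the same atoms and bonds; at least one stereo element is drawn with a configuration in one of them and without one in the other: 1 of 1 stereo elements differ; a stereocentre at a saturated chain carbon is drawn without a configuration in compound 2 and S in compound 3. The measured step bears on it directly: it shows that drawing the stereocentre as R gives a lower number than the undefined drawing, so the S drawing is expected to move the other way in this assay, beyond the scatter and by more than the measured step. Compound 3 is therefore estimated at 1500 nM, within 400 nM to 8000 nM, which means an expected step of a 6.3-fold higher number from compound 2 to compound 3 (0.80 log units; beyond the scatter).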

Compound 3, half-maximal effective concentration: 410 nM
Compound 3: middle estimate off by 3.7-fold (0.56 log units), on the high side, within the range that was stated.
By their numbers in this assay, from the lowest: compound 1; then compounds 2 and 3 (each within the scatter of the next).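

In this assay the two defined drawings can now be compared directly, with a 5.1-fold higher number from compound 1 to compound 3 (0.70 log units; beyond the scatter), so the R drawing gives the lower number of the pair, and the whole gap rests on configuration alone: the fact that compounds 1 and 3 differ only in the configuration as drawn

The S drawing does not separate from the undefined drawing, with a 1.7-fold higher number from compound 2 to compound 3 (0.23 log units; within the scatter). Compound 1 is therefore the only one of the three whose number stands clear of both others, which places the difference at this stereocentre on the R drawing.

From the compounds shown here alone, what compound 2 contains as drawn, a single form or a mixture, stays open, so its number cannot be apportioned between the R and S forms. Also open, going by these compounds, is whether the preference for R holds with a cyclopropyl group or a nitrile in place of the alkyne at this stereocentre.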